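Amide to Hydrazide: Expected Cytotoxicity of Compound 4

The source may hold more compounds than are shown below. What is called first, only, known or untested is meant among the compounds shown, and "the series" means these compounds.

Compound 1 `O=C(CSCc1nc2cc([N+](=O)[O-])ccc2[nH]1)c1ccccc1` gives 12400 nM in a functional assay on HCT-116 cells (Homo sapiens) for cytotoxicity, read by MTT assay, with a stated time of 48 h; a lower number here means a stronger inhibitor, a higher number a weaker inhibitor. Compound 2 `N#CCSCc1nc2cc([N+](=O)[O-])ccc2[nH]1` gives 28200 nM in this assay. Compound 3 `NC(=O)CSCc1nc2cc([N+](=O)[O-])ccc2[nH]1` gives 17200 nM in this assay.

Compound 3 stands second highest of the three numbers, and both of its neighbours sit within the scatter: a 1.4-fold higher number from compound 1 to compound 3 (0.14 log units; within the scatter) and a 1.6-fold lower number from compound 2 to compound 3 (0.21 log units; within the scatter). Compound 4 `NNC(=O)CSCc1nc2cc([N+](=O)[O-])ccc2[nH]1` differs from compound 3 by amino in place of hydrogen on an amide-type nitrogen. Among the compounds with values here, no measured step repeats this exact change, but the two known steps, each altering the same end of the chain, barely moved the number. A step of similar small size, with no clear direction, is expected: a 1.1-fold lower number from compound 3 to compound 4 (0.06 log units; within the scatter). Compound 4 is estimated at 15000 nM, expected to fall between 6000 nM and 40000 nM.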

Compound 4, half-maximal inhibitory concentration: 5330 nM
Estimate against measurement, compound 4: 2.8-fold (0.45 log units) above; the measured number lies below the stated range.
By their numbers in this assay, from the lowest: compound 4; then compounds 1, 3 and 2 (each within the scatter of the next, the first and the last beyond it).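

In this assay, an amino group in place of the hydrogen on the amide-type nitrogen gives a 3.2-fold lower number from compound 3 to compound 4 (0.51 log units; beyond the scatter), the first change at this end of the chain shown to go beyond the scatter. Compound 4 also stands apart from the other two compounds, with a 5.3-fold lower number from compound 2 to compound 4 (0.72 log units; beyond the scatter) and a 2.3-fold lower number from compound 1 to compound 4 (0.37 log units; beyond the scatter), making it the strongest inhibitor of the four, though only modestly. This nitrogen therefore responds to one added amino group.

Nothing shown here explains the step. As far as these compounds go, whether a methyl group on that same nitrogen would give a similar step remains open.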